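The source may hold more compounds than are shown below. What is called first, only, known or untested is meant among the compounds shown, and "the series" means these compounds.

Measured so far in a functional assay on UACC-62 cells (Homo sapiens) for inhibition, read by sulforhodamine B assay, with a stated time of 48 h; on this read-out higher numbers stand for weaker inhibition of growth and lower numbers for stronger inhibition of growth:
compound 1, `CN1CCN(CCCOc2cccc3nc(Nc4ccc(Cl)c(C(F)(F)F)c4)ccc23)CC1`, gives 1720 nM
compound 2, `CN1CCN(CCCOc2cccc3nc(Nc4ccc(Cl)c(F)c4)ccc23)CC1`, gives 2050 nM
compound 3, `CN1CCN(CCCOc2cccc3nc(Nc4ccc(F)c(F)c4)ccc23)CC1`, gives 700 nM

Compound 3 stands lowest of the three in this assay, and both of its distances lie beyond the scatter: the step of a 2.5-fold lower number from compound 1 to compound 3 (0.39 log units; beyond the scatter) and the step of a 2.9-fold lower number from compound 2 to compound 3 (0.47 log units; beyond the scatter). Compound 4, `CN1CCN(CCCOc2cccc3nc(Nc4cc(Cl)cc(Cl)c4)ccc23)CC1`, has not yet been measured. It differs from compound 3 by 3,5-dichlorophenyl in place of 3,4-difluorophenyl on a nitrogen on an aromatic ring.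

Within the data shown here, two measured steps bear on this change. The step of a 2.9-fold lower number from compound 2 to compound 3 (0.47 log units; beyond the scatter) shows that putting fluoro in place of chloro lowered the number; compound 4 goes the other way, with two chlorines in place of two fluorines, though the arrangement of the substituents on the ring also changes. The step of a 2.5-fold lower number from compound 1 to compound 3 (0.39 log units; beyond the scatter) likewise shows the 3,4-difluorophenyl giving the lowest number among the three aryl groups. Against this, the step of a 1.2-fold higher number from compound 1 to compound 2 (0.08 log units; within the scatter) lies within the scatter, so exchanging one halogenated group for another did not always move the number.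

Compound 4 is therefore expected to give a modestly higher number than compound 3, a step of about a 2.1-fold higher number from compound 3 to compound 4 (0.33 log units; beyond the scatter). The estimate for compound 4 in this assay is 1500 nM, with a range from 600 nM to 4000 nM.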

Compound 4, concentration for 50% growth inhibition: 1950 nM
Beside the measured number, compound 4's estimate is 1.3-fold (0.11 log units) below it; measured number inside the range.
By their numbers in this assay, from the lowest: compound 3; then compounds 1, 4 and 2 (each within the scatter of the next).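

In this assay the 3,5-dichlorophenyl group on this nitrogen does not keep the standing of the 3,4-difluorophenyl group (a 2.8-fold higher number from compound 3 to compound 4 (0.44 log units; beyond the scatter)). It instead falls level with the other two aryl groups (a 1.1-fold lower number from compound 2 to compound 4 (0.02 log units; within the scatter); a 1.1-fold higher number from compound 1 to compound 4 (0.05 log units; within the scatter)), so compound 3 now stands apart from all three other compounds, with each of its steps beyond the scatter. Among these four compounds, the three aryl groups that carry chlorine lie within the scatter of one another, and compound 3, the only one without chlorine, is the sole exception, though nothing shown here gives a reason for this separation.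

The four compounds cannot separate the kind of halogen from its arrangement on the ring, a question that a 3,5-difluorophenyl or a 3,4-dichlorophenyl group on this nitrogen would address. Also open, from the compounds shown here alone, is how an unsubstituted phenyl group or a methoxyphenyl group would compare with the 3,4-difluorophenyl group in this position.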